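Replacing the thioether arm of compound 3 with an ethylpiperazine

The source may report more compounds than this note shows. Statements on the series, on what has been measured and on what is new or still open speak of the compounds shown alone.

Three amides sharing one core were measured in a functional assay on HT-29 cells (Homo sapiens) for cytotoxicity, read by MTT assay, with a stated time of 24 h, tested at 6.4 ug/mL; a higher number here means a stronger effect of the compound at the concentration tested, a lower number a weaker effect. Compound 1 `Cn1c(-c2ccc(NC(=O)CSc3nc4cc(Cl)ccc4o3)cc2)nc(-c2ccccc2)c1-c1ccccc1` gives 29.4%, compound 2 `Cn1nnnc1SCC(=O)Nc1ccc(-c2nc(-c3ccccc3)c(-c3ccccc3)n2C)cc1` gives 60.6%, and compound 3 `Cc1nnc(SCC(=O)Nc2ccc(-c3nc(-c4ccccc4)c(-c4ccccc4)n3C)cc2)s1` gives 73%. Compound 3 stands highest of the three: the step of a number 12.4 percentage points higher from compound 2 to compound 3 (beyond the scatter) and the step of a number 43.6 percentage points higher from compound 1 to compound 3 (beyond the scatter) both lie beyond the scatter, so the ring carried on the sulfur clearly matters to the read-out.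

Compound 4 `CCN1CCN(CC(=O)Nc2ccc(-c3nc(-c4ccccc4)c(-c4ccccc4)n3C)cc2)CC1` goes further than either of those swaps. Here the change is 4-ethylpiperazin-1-yl in place of (5-methyl-1,3,4-thiadiazol-2-yl)sulfanyl on a saturated chain carbon bound to a carbonyl carbon. For the measured compounds named here, none of the measured steps tests this kind of exchange, since all three measured compounds keep a sulfur-linked aromatic ring; they only show that changing that ring moves the number by a large amount, as in a number 43.6 percentage points higher from compound 1 to compound 3 (beyond the scatter) and a more modest amount, as in a number 12.4 percentage points higher from compound 2 to compound 3 (beyond the scatter). With the sulfur and its ring gone altogether, a sizeable move is expected, and because the highest number belongs to compound 3 at 73%, the more likely direction is downward. The expected step is a number 28 percentage points lower from compound 3 to compound 4 (beyond the scatter). Compound 4 is therefore estimated at 45%, with a range from 15% to 75%.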

Compound 4, a percentage reported as activity, at one concentration (the size of the read-out at that concentration, not a potency): 17.2%
For compound 4 the middle estimate is 27.8 percentage points above the measured one; low and high end bracket the measured number.
By their numbers in this assay, from the lowest: compound 4; then compound 1; then compound 2; then compound 3.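

In this assay, the chain carbon bound to a carbonyl carbon proves sensitive not only to which ring the sulfur carries but also to whether a sulfur-linked ring is present at all: the exchange for 4-ethylpiperazin-1-yl gives a number 55.8 percentage points lower from compound 3 to compound 4 (beyond the scatter) and a number 43.4 percentage points lower from compound 2 to compound 4 (beyond the scatter). Even the sulfur-linked compound with the lowest number stays ahead of the piperazine (a number 12.2 percentage points lower from compound 1 to compound 4 (beyond the scatter)), so compound 4 falls below all three thioethers, and none of them goes against this order. The shared core and amide therefore do not fix the read-out on their own, yet nothing shown here explains why this exchange lowers the number so far.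

The compounds shown leave open whether the fall belongs to the loss of the sulfur, the loss of the five-membered aromatic ring, or the arrival of the piperazine with its ethyl group. A morpholine or an unsubstituted piperazine on the same carbon, or a sulfur carrying a simple methyl group, would help to separate these changes, and all of these readings rest on a single concentration.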